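Fluoro Gives Way to Amino on an Aromatic Ring

A few compounds are considered here, and "the series" means these few. Any claim that something is new, unique, unknown or untested is made for them only; others in the source may bear on it.

Of the compounds shown here, two on a shared core have been measured so far. In a functional assay on HCT-116 cells (Homo sapiens) for cytotoxicity, read by MTT assay, with a stated time of 48 h (a higher number here means a weaker inhibitor, a lower number a stronger inhibitor), compound 1 (`COc1cc(C(=O)c2cn(-c3cccc(N)c3)cc2-c2ccc(N)cc2)cc(OC)c1OC`) gives 27 nM and compound 2 (`COc1cc(C(=O)c2cn(-c3ccc(F)cc3)cc2-c2ccc(N)cc2)cc(OC)c1OC`) gives 36 nM as its value. Among the compounds with values here, compound 2 therefore stands within the scatter of compound 1, its only measured neighbour. Compound 3 (`COc1cc(C(=O)c2cn(-c3ccc(N)cc3)cc2-c2ccc(N)cc2)cc(OC)c1OC`) has yet to be measured in this assay and differs from compound 2 by one exchange (amino in place of fluoro on an aromatic carbon): amino in place of fluoro on an aromatic carbon, para to a large group, which turns 4-fluorophenyl into 4-aminophenyl. Within the data shown here, only one measured step bears on this (a 1.3-fold higher number from compound 1 to compound 2 (0.12 log units; within the scatter)). There 4-fluorophenyl took the place of an aminophenyl group on the aromatic nitrogen, so compound 1 also carries an amino group on that ring. Among the measured compounds shown here, no measured pair isolates the exchange at this exact carbon. A step beyond the scatter is therefore not expected, and the estimated change is small (a 1.2-fold lower number from compound 2 to compound 3 (0.08 log units; within the scatter)). The estimate for compound 3 is 30 nM with an expected range (12 nM to 75 nM).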

Compound 3, half-maximal inhibitory concentration: 41 nM
Estimate against measurement, compound 3: 1.4-fold (0.14 log units) below, within the range that was stated.
By their numbers in this assay, from the lowest: compounds 1, 2 and 3 (each within the scatter of the next).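

In this assay, the exchange of fluoro for amino on an aromatic carbon, para to a large group, now has a pair of its own: it gives a 1.1-fold higher number from compound 2 to compound 3 (0.06 log units; within the scatter) and so does not separate 4-fluorophenyl from 4-aminophenyl in this assay. The place of the amino group on this ring can now be read as well, since 4-aminophenyl in place of the aminophenyl group of compound 1 gives a 1.5-fold higher number from compound 1 to compound 3 (0.18 log units; within the scatter) and the two placements shown cannot be told apart. No available measurement explains why these exchanges leave the numbers within the scatter.

What the three compounds leave open is whether this tolerance reaches beyond fluoro and amino at this carbon, as a carboxylic acid, a dimethylamino group or a longer chain such as butoxy would show. From the compounds shown here alone, the second amino group, which all three compounds carry, stays the same throughout, so it also remains open how a hydroxyl or a methoxy group in its place would read.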